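Methyl on compound 1: expected step in growth inhibition

The source may hold more compounds than are shown below. What is called first, only, known or untested is meant among the compounds shown, and "the series" means these compounds.

- compound 1 `Oc1cc(-c2ccc3ccccc3c2)nc2ncccc12`: 3800 nM
- compound 2 `Cc1cc(C)c2c(O)cc(-c3cccc(Cl)c3)nc2n1`: 224 nM
- compound 3 `Cc1cnc2[nH]c(-c3cccc(Cl)c3)cc(=O)c2c1`: 50.1 nM

In a functional assay on NCI-H460 cells (Homo sapiens) for antiproliferative activity (on this read-out higher numbers stand for weaker inhibition of growth and lower numbers for stronger inhibition of growth), compound 1 stands highest of the three, and compound 2 and compound 3 both lie lower, beyond the scatter. Compound 4 `Cc1ccnc2nc(-c3ccc4ccccc4c3)cc(O)c12` is not yet measured. It differs from compound 1 by one change: methyl in place of hydrogen on an aromatic carbon, opposite the ring nitrogen. Among the measured compounds shown here, no measured pair isolates this change. Compound 2, at 224 nM, and compound 3, at 50.1 nM, carry methyl but also differ elsewhere, so they offer only a weak hint. A modest fall in the number is expected, possibly within the scatter. The estimated step is a 1.9-fold lower number from compound 1 to compound 4 (0.28 log units; within the scatter). Compound 4 is expected at 2000 nM, within an estimated range of 400 nM to 8000 nM.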

Compound 4, concentration for 50% growth inhibition: 1050 nM
Estimate against measurement, compound 4: 1.9-fold (0.28 log units) above, and the stated range covers the measured number.
By their numbers in this assay, from the lowest: compound 3; then compound 2; then compound 4; then compound 1.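

In this assay, among the compounds shown here, methyl in place of hydrogen on an aromatic carbon, opposite the ring nitrogen, gives a 3.6-fold lower number from compound 1 to compound 4 (0.56 log units; beyond the scatter) and so provides the first reading of this single change. This position accepts the added methyl, and growth inhibition is stronger by a modest step beyond the scatter. Nothing available explains the step.

Going by these compounds, whether an ethyl group, a methoxy group or an amine on the same carbon would move the number further remains open. Also open, on these data alone, is whether methyl gives a similar step on other cores.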